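Thiophen-3-yl for furan-3-yl at the assay limit

A few compounds are considered here, and "the series" means these few. Any claim that something is new, unique, unknown or untested is made for them only; others in the source may bear on it.

Compound 2 (`Cc1nc(N)c2c(-c3ccoc3)cn([C@@H]3O[C@H](CO)[C@@H](O)[C@H]3O)c2n1`) stands at > 20000 nM in a functional assay on K562 cells (Homo sapiens), read by MTT assay, with a stated time of 72 h (a higher number here means a weaker inhibitor, a lower number a stronger inhibitor), as a limit of the assay and not as a number. Compound 1 (`Nc1nc(N)c2c(-c3ccsc3)cn([C@@H]3O[C@H](CO)[C@@H](O)[C@H]3O)c2n1`) gives > 20000 nM in this assay and that too is a limit. Among the measured compounds shown here, the tally (the limit of > 20000 nM in this assay, at which 2 of the 2 values shown sit) leaves the series without a numeric value so far. Compound 3 (`Cc1nc(N)c2c(-c3ccsc3)cn([C@@H]3O[C@H](CO)[C@@H](O)[C@H]3O)c2n1`) has thiophen-3-yl in place of furan-3-yl on an aromatic carbon. For the measured compounds named here, with no measured step to go on, a change no larger than the scatter is expected in this assay in either direction. The expected move is a number no higher from compound 2 to compound 3 (the limit leaves the size open) as estimated here. For compound 3 the estimate is 20000 nM with an expected range from 7000 nM to 40000 nM and a report as a limit is likely.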

Compound 3, half-maximal inhibitory concentration: > 20000 nM
Compound 3 was reported as a limit; the forecaster's own chance of this, stated with the estimate: 85%; the middle value sits exactly at the limit.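

Neither the change from compound 1 to compound 3 nor that from compound 2 to compound 3 can be read, as all three values are limits: the limit of > 20000 nM in this assay, at which 3 of the 3 values shown sit. The compounds shown leave open whether either change alters potency in this assay.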